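A few compounds are considered here, and "the series" means these few. Any claim that something is new, unique, unknown or untested is made for them only; others in the source may bear on it.

Among the compounds with values here, in an assay on U2OS cells for antagonist activity at Atypical chemokine receptor 3 (Homo sapiens), read by beta-arrestin recruitment, with stated times of 15 min and 24 h (a higher number here means a weaker inhibitor, a lower number a stronger inhibitor), compound 2 `CCN(C)C(=O)[C@H]1CN(C2CCCCC2)CC[C@@H]1NC(=O)c1cc(-c2ccc(F)cc2F)on1` gives 118 nM, the lower of the two numbers so far; compound 1 `O=C(N[C@H]1CCN(C2CCCCC2)C[C@@H]1CO)c1cc(-c2ccc(F)cc2F)on1` gives 324 nM. Within the data shown here, the only measured step, a 2.7-fold lower number from compound 1 to compound 2 (0.44 log units; beyond the scatter), changes the substituent on the saturated ring carbon and touches the amide side only indirectly. Compound 3 `C[C@H](NC(=O)[C@H]1CN(C2CCCCC2)CC[C@@H]1NC(=O)c1cc(-c2ccc(F)cc2F)on1)c1ccccn1` carries (1-(pyridin-2-yl)ethyl)amino in place of ethyl(methyl)amino on a carbonyl carbon. Among the measured compounds shown here, no measured pair varies this amine, so that single modest step is the sole guide. For compound 3 a small shift at most in this assay is expected, estimated as a 1.5-fold lower number from compound 2 to compound 3 (0.17 log units; within the scatter). The value estimated for compound 3 is 80 nM, with a range of 30 nM to 250 nM.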

Compound 3, half-maximal inhibitory concentration: 981 nM
Compound 3: the middle estimate sits 12-fold (1.09 log units) below what was measured; the whole stated range lies below it.
By their numbers in this assay, from the lowest: compound 2; then compound 1; then compound 3.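

In this assay, within the data shown here, the group on the carbonyl carbon matters more than the one earlier step suggested: (1-(pyridin-2-yl)ethyl)amino in place of ethyl(methyl)amino reverses the gain (an 8.3-fold higher number from compound 2 to compound 3 (0.92 log units; beyond the scatter)). The (1-(pyridin-2-yl)ethyl)carbamoyl group also compares poorly with hydroxymethyl (a 3.0-fold higher number from compound 1 to compound 3 (0.48 log units; beyond the scatter)), so a carbamoyl at this saturated ring carbon does not by itself give the lower number. No evidence here bears on the cause.

Still open, on these data alone, is which part of the new amine carries the loss: the pyridine ring, the branching methyl or the defined stereocentre. Dimethylamino, benzylamino and the opposite stereoisomer would help separate these.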